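Swapping a fluorobenzyl arm: cytotoxicity on mouse fibroblasts

The source may hold more compounds than are shown below. What is called first, only, known or untested is meant among the compounds shown, and "the series" means these compounds.

Measured so far:
- compound 1 `COC(=O)c1ccc(NCc2cncn2Cc2cccc(F)c2)cc1-c1ccccc1`: > 1000 nM
- compound 2 `COc1ccc(NCc2cncn2Cc2ccc(-c3ccccc3)cc2)cc1-c1ccccc1`: > 1000 nM

In a toxicity assay on NIH3T3 cells (Mus musculus) for cytotoxicity, read by resazurin assay (a higher number here means that more compound is needed for the effect, a lower number that less compound is needed), compound 1 gives only a limit, > 1000 nM. Compound 2 likewise gives only a limit in this assay, > 1000 nM. Neither value is a number, so compound 1 cannot be placed against compound 2; both sit at the limit of > 1000 nM in this assay, at which 2 of the 2 values shown sit.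

Compound 3 `COC(=O)c1ccc(NCc2cncn2Cc2ccc(F)cc2F)cc1-c1ccccc1` is not yet measured. It differs from compound 1 in one place: 2,4-difluorophenyl in place of 3-fluorophenyl on a saturated chain carbon bound to an aromatic nitrogen.

Among the compounds with values here, with no step between measured compounds to draw on, the expectation rests on the two limits alone. For compound 3 the step that the limit leaves unreadable from compound 1 to compound 3 is expected to be nothing beyond the usual scatter. Compound 3 is therefore estimated at 1500 nM, within 700 nM to 5000 nM, and most likely reported again as a limit rather than a number.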

Compound 3, half-maximal effective concentration: > 1000 nM
Compound 3 was reported as a limit; the forecaster's own chance of this, stated with the estimate: 80%; the middle value is on the limit's open side.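

Compound 3 and compound 1 both give only a limit in this assay, so no step can be read between them, because neither value is a number: the limit of > 1000 nM in this assay, at which 3 of the 3 values shown sit.

The compounds shown leave open what concentration of any of them produces the effect, and whether 2,4-difluorophenyl and 3-fluorophenyl differ at all.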